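Chloro to methoxy on the aryl ring, on two cores

This account rests on a few compounds, and the source may have more. Where it says the series, first, only, none or still open, it means among the compounds named here.

Compound 1 `CCn1cc(-c2cccc(Cl)c2)c(=O)c2cc(F)c(N3CCNCC3)cc21` and compound 2 `CCn1cc(-c2cccc(OC)c2)c(=O)c2cc(F)c(N3CCNCC3)cc21` share one core; compound 3 `O=c1c(-c2ccc(Cl)cc2)cn(C2CC2)c2cc(N3CCNCC3)c(F)cc12` and compound 4 `COc1ccc(-c2cn(C3CC3)c3cc(N4CCNCC4)c(F)cc3c2=O)cc1` share another. How the two cores differ is not broken down here. In a functional assay on HeLa cells (Homo sapiens) for antiproliferative activity, read by MTT assay, with a stated time of 48 h (a lower number here means a stronger inhibitor, a higher number a weaker inhibitor), compound 1 gives 16100 nM, and compound 2 gives 12200 nM. The change between them is methoxy in place of chloro on an aromatic carbon, and it made a step of a 1.3-fold lower number from compound 1 to compound 2 (0.12 log units; within the scatter). In this assay compound 3 gives 9300 nM; its number sits nearest that of compound 2 and furthest from that of compound 1, both gaps within the scatter. Compound 4 carries the change methoxy in place of chloro on an aromatic carbon on the core of compound 3. This is the same kind of change as that in the measured pair, not the same: there the group sits meta to a large group, here para to a large group. The expected step is a 1.2-fold lower number from compound 3 to compound 4 (0.09 log units; within the scatter), and it is expected to stay small because a 1.3-fold lower number from compound 1 to compound 2 (0.12 log units; within the scatter) stayed within the scatter. For compound 4 the estimate in this assay is 7500 nM, with a range from 3500 nM to 16000 nM.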

Compound 4, half-maximal inhibitory concentration: 16500 nM
For compound 4 the middle estimate is 2.2-fold (0.34 log units) below the measured one; the measured number lies above the stated range.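

In this assay, methoxy in place of chloro gives a 1.8-fold higher number from compound 3 to compound 4 (0.25 log units; within the scatter), so 4-chlorophenyl to 4-methoxyphenyl stays within the scatter on this core, as the same kind of change does on the core of compound 1. Set side by side, the two steps point in opposite directions, but that difference carries no weight, and neither core can be said to respond differently from the other: the same change on two cores in this assay, a 1.3-fold lower number (0.12 log units; within the scatter) from compound 1 to compound 2 and a 1.8-fold higher number (0.25 log units; within the scatter) from compound 3 to compound 4, 2.3-fold (0.37 log units) apart, within the scatter of two such steps This supports only a narrow reading, that the change leaves no readable mark on either core; it does not show that a real effect carries over, and the two pairs also differ in where the group sits on the aryl ring.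

The compounds shown leave open whether any substituent at this position moves the antiproliferative read-out beyond the scatter, for example an amine, a carboxylic acid or a longer alkoxy chain in place of methoxy. They also leave open whether chloro and methoxy at one fixed place on the aryl ring would behave alike across the two cores.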